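This account rests on a few compounds, and the source may have more. Where it says the series, first, only, none or still open, it means among the compounds named here.

Working notes on the series. In a functional assay on A549 cells (Homo sapiens) for antiproliferative activity, read by sulforhodamine B assay, with a stated time of 72 h (a lower number here means a stronger inhibitor, a higher number a weaker inhibitor), compound 1 `COc1ccc(/C=C2\CCC=CC2=O)cc1` gives 1460 nM and compound 2 `COc1cccc(/C=C2\CCC=CC2=O)c1` gives 1480 nM, two values within the scatter of each other. Compound 3 `COc1ccc(/C=C2\CCC=CC2=O)cc1OC` has the highest number of the three at 4680 nM, which makes it the weakest so far.

The next change leads to compound 4 `COc1ccc(/C=C2\CCC=CC2=O)cc1[N+](=O)[O-]`: nitro in place of methoxy on an aromatic carbon. This is nitro in place of methoxy on an aromatic carbon, ortho to a methoxy group.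

The closest measured steps are both methoxy in place of hydrogen on an aromatic carbon: a 3.2-fold higher number from compound 1 to compound 3 (0.51 log units; beyond the scatter) and a 3.2-fold higher number from compound 2 to compound 3 (0.50 log units; beyond the scatter). Both are modest and beyond the scatter. Within the data shown here, no measured compound carries a nitro group, so the size of its contribution is unknown and the range must stay wide. With the methoxy of compound 3 gone, a modest move towards a lower number is expected, no larger than those two steps.

The expected step is a 2.0-fold lower number from compound 3 to compound 4 (0.31 log units; beyond the scatter).

For compound 4 the estimated value is 2300 nM, with an expected range of 750 nM to 7000 nM.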

Compound 4, half-maximal inhibitory concentration: 1480 nM
For compound 4 the middle estimate is 1.6-fold (0.19 log units) above the measured one; the measured number falls inside the stated range.
By their numbers in this assay, from the lowest: compounds 1, 2 and 4 (each within the scatter of the next); then compound 3.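

In this assay, nitro in place of methoxy on the aromatic carbon ortho to a methoxy group gives a 3.2-fold lower number from compound 3 to compound 4 (0.50 log units; beyond the scatter) and so reverses the rise that methoxy in place of hydrogen gave on this same carbon in a 3.2-fold higher number from compound 1 to compound 3 (0.51 log units; beyond the scatter) within the series. Nitro in place of hydrogen on this carbon gives a 1.0-fold higher number from compound 1 to compound 4 (0.01 log units; within the scatter) in this pair, so of the two groups seen here, only methoxy moves the number away from that of compound 1. The rise seen with compound 3 therefore does not hold for every group on this carbon, since nitro has more heavy atoms than methoxy and shows no such rise.

As far as these compounds go, whether an amine or a carboxylic acid on this carbon would also stay level with compound 1 remains open. Nothing available here explains why methoxy and nitro differ on this carbon.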